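Sulfonyl aryl variation on a shared aminoquinazoline core

This account rests on a few compounds, and the source may have more. Where it says the series, first, only, none or still open, it means among the compounds named here.

Compound 1 `COc1cc2nc(N3CCN(S(=O)(=O)c4ccc(Cl)cc4)CC3)nc(N)c2cc1OC`: 23000 nM
Compound 2 `COc1cc2nc(N3CCN(S(=O)(=O)c4cccc([N+](=O)[O-])c4)CC3)nc(N)c2cc1OC`: 32000 nM
Compound 3 `COc1cc2nc(N3CCN(S(=O)(=O)c4cccc(C(=O)O)c4)CC3)nc(N)c2cc1OC`: 53000 nM

Three compounds sharing one core were measured in a functional assay on PC-3 cells (Homo sapiens) for inhibition; on this read-out lower numbers stand for stronger inhibition and higher numbers for weaker inhibition. Compound 1 gives 23000 nM, compound 2 gives 32000 nM, and compound 3 gives 53000 nM. Compound 3 stands at the highest number of the three: one step reaches it within the scatter, a 1.7-fold higher number from compound 2 to compound 3 (0.22 log units; within the scatter), and the other reaches it beyond the scatter, a 2.3-fold higher number from compound 1 to compound 3 (0.36 log units; beyond the scatter).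

Compound 4 `COc1cc2nc(N3CCN(S(=O)(=O)c4cc(Cl)ccc4Cl)CC3)nc(N)c2cc1OC` is not yet measured. It differs from compound 3 in one place: 2,5-dichlorophenyl in place of 3-carboxyphenyl on a sulfonyl sulfur. Going by the values given here, the step that bears most closely on this is the one from compound 1 to compound 3, a 2.3-fold higher number from compound 1 to compound 3 (0.36 log units; beyond the scatter), which swaps a chlorophenyl for the carboxyphenyl; the step from compound 2 to compound 3, a 1.7-fold higher number from compound 2 to compound 3 (0.22 log units; within the scatter), points the same way but stays within the scatter. Reversing the carboxyphenyl for a dichlorophenyl is therefore expected to give a modestly lower number in this assay, about a 2.7-fold lower number from compound 3 to compound 4 (0.42 log units; beyond the scatter). Compound 4 is estimated at 20000 nM, with a likely range from 8000 nM to 50000 nM.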

Compound 4, half-maximal inhibitory concentration: 60000 nM
Estimate against measurement, compound 4: 3.0-fold (0.48 log units) below, outside the stated range (above it).
By their numbers in this assay, from the lowest: compounds 1, 2, 3 and 4 (each within the scatter of the next, the first and the last beyond it).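

In this assay, 2,5-dichlorophenyl on the sulfonyl sulfur gives a 1.1-fold higher number from compound 3 to compound 4 (0.05 log units; within the scatter), so exchanging the 3-carboxyphenyl, with its hydrogen-bond donor and acceptor, for a ring of carbon and chlorine alone produces no step beyond the scatter. The step from the 3-nitrophenyl also stays within the scatter, a 1.9-fold higher number from compound 2 to compound 4 (0.27 log units; within the scatter), while the one from the 4-chlorophenyl is modest but beyond it, a 2.6-fold higher number from compound 1 to compound 4 (0.42 log units; beyond the scatter), so chlorine on the phenyl ring does not by itself keep the number where the 4-chlorophenyl has it. Nothing available explains these steps.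

From the compounds shown here alone, it remains open how an amine or a methoxy group on the phenyl ring, or a methyl group in place of the ring on the sulfonyl sulfur, would read here. Going by these compounds, it is also open whether any group at this place would give a number well under that of compound 1, 23000 nM.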